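The compounds below may be only part of what the source reports. "The series", "measured", "known", "first", "only" and "open" are said of these compounds alone.

Of the compounds shown here, two with a shared core have been measured in a functional assay on L6 cells (Rattus norvegicus) for cytotoxicity; on this read-out higher numbers stand for weaker inhibition and lower numbers for stronger inhibition. Compound 1 `C[C@H](NC(=O)Cn1ccc(=O)[nH]c1=O)C(=O)N[C@@H](CC(=O)O)C(=O)O` gives > 252000 nM, which is a limit of the assay and not a number. Compound 2 `C[C@H](NC(=O)Cn1ccc(=O)[nH]c1=O)C(=O)N[C@@H](CCCCN)C(=O)O` gives > 243000 nM, which is also a limit, so its standing can be told only as a limit. Compound 3 `CC(O)[C@H](NC(=O)[C@H](C)NC(=O)Cn1ccc(=O)[nH]c1=O)C(=O)O` has not been measured yet. It carries 1-hydroxyethyl in place of 4-aminobutyl on a saturated chain carbon bound to an amide-type nitrogen and a carbonyl carbon. Among the measured compounds shown here, only one measured step bears on this change: a step that the two limits leave unreadable from compound 1 to compound 2, with 3-aminopropyl in place of carboxy. That step offers no size to carry over, and on this thin basis no step beyond the scatter is expected in this assay, in either direction. The estimated move is a step that the limit leaves unreadable from compound 2 to compound 3, which is expected to be too small to read. For compound 3 the expected value is 263000 nM, with an estimated range of 150000 nM to 400000 nM, and the assay is expected to report it only as a limit.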

Compound 3, half-maximal inhibitory concentration: > 262000 nM
Compound 3: a limit, no number; the forecaster's own chance of this, stated with the estimate: 90%; the middle value lies beyond the limit too.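

In this assay, among the compounds shown here, compound 1, compound 2 and compound 3 each give only a limit and not a number, so no step among them can be read. The compounds shown leave open at what concentration, if any, these compounds inhibit the cells, and whether the changes in side chain make any difference.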